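This account rests on a few compounds, and the source may have more. Where it says the series, first, only, none or still open, it means among the compounds named here.

Compound 1 `O=C(Nc1ccc(C(F)(F)F)cc1)Nc1cc2ncncc2cc1OCc1cccc(F)c1`: 6300 nM
Compound 2 `O=C(Nc1ccc(C(F)(F)F)cc1)Nc1cc2ncncc2cc1OCc1cccc(Cl)c1`: 5100 nM
Compound 3 `O=C(Nc1ccc(C(F)(F)F)cc1)Nc1cc2ncncc2cc1OCc1ccccc1`: 3700 nM

In a functional assay on GBM3 cells (Homo sapiens) for antiproliferative activity, read by WST assay, with a stated time of 72 h (a higher number here means a weaker inhibitor, a lower number a stronger inhibitor), compound 1 stands level with compound 2 and compound 3, all three lying within the scatter of one another. Compound 4 `O=C(Nc1cc2ncncc2cc1OCc1cccc(F)c1)Nc1cccc2ccccc12` differs from compound 1 as follows: naphthalen-1-yl in place of 4-(trifluoromethyl)phenyl on an amide-type nitrogen. The measured steps, a 1.2-fold lower number from compound 1 to compound 2 (0.09 log units; within the scatter), a 1.7-fold lower number from compound 1 to compound 3 (0.23 log units; within the scatter) and a 1.4-fold lower number from compound 2 to compound 3 (0.14 log units; within the scatter), all stay within the scatter. They exchange fluoro, chloro and hydrogen on an aromatic carbon elsewhere, and none changes the group on this nitrogen. They therefore give no direct measure of this change and no direction, so no step beyond the scatter is expected, with wide uncertainty. The expected change is a 1.3-fold lower number from compound 1 to compound 4 (0.10 log units; within the scatter). For compound 4 the estimate is 5000 nM, with an expected range of 1500 nM to 15000 nM.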

Compound 4, half-maximal inhibitory concentration: 1200 nM
Estimate against measurement, compound 4: 4.2-fold (0.62 log units) above, outside the stated range (below it).
By their numbers in this assay, from the lowest: compound 4; then compounds 3, 2 and 1 (each within the scatter of the next).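

Within the data shown here, the nitrogen of the urea-like link is the first place where a change moves this assay beyond the scatter: naphthalen-1-yl in place of 4-(trifluoromethyl)phenyl gives a 5.3-fold lower number from compound 1 to compound 4 (0.72 log units; beyond the scatter). The exchanges of fluoro, chloro and hydrogen elsewhere had stayed within the scatter, so this amide-type nitrogen is the more responsive of the two places shown. No available measurement accounts for this step.

Open, from the compounds shown here alone, is whether the second aromatic ring or the loss of trifluoromethyl carries the step, which unsubstituted phenyl or naphthalen-2-yl on this nitrogen would help separate. Also open, going by these compounds, is whether the chloro and hydrogen exchanges behave the same with naphthalen-1-yl in place.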